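Methyl on the sulfonamide nitrogen of a weakly binding urea

The source may report more compounds than this note shows. Statements on the series, on what has been measured and on what is new or still open speak of the compounds shown alone.

Two measured compounds frame this step. Compound 1 `COc1ccc2c(c1)CC(N(CCCN1CCN(C)CC1)C(=O)Nc1ccc(F)c(Cl)c1)CC2` binds in an assay on CHO cells for binding affinity to melanin-concentrating hormone receptor 1 (Homo sapiens) (a higher number here means a weaker inhibitor, a lower number a stronger inhibitor), with 92 nM, whereas compound 2 `CNS(=O)(=O)c1ccc2c(c1)CC(N(CCCN1CCN(C)CC1)C(=O)Nc1ccc(F)c(Cl)c1)CC2` gives 3000 nM in this assay. Within the data shown here, the only measured step, a 33-fold higher number from compound 1 to compound 2 (1.51 log units; beyond the scatter), is large, and it leaves compound 2 with the highest number of the two and its nearest neighbour, compound 1, far below it.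

Compound 3 `CN1CCN(CCCN(C(=O)Nc2ccc(F)c(Cl)c2)C2CCc3ccc(S(=O)(=O)N(C)C)cc3C2)CC1` keeps everything of compound 2 except one change: methyl in place of hydrogen on a sulfonamide nitrogen. Among the measured compounds shown here, no measured pair touches this kind of change; the one step that exists swaps the whole group on the aromatic carbon and does not show what adding a methyl to the sulfonamide nitrogen does. With nothing to build on but the size of the group entering, the expectation for compound 3 in this assay is a number close to that of compound 2, a step of a 1.1-fold lower number from compound 2 to compound 3 (0.03 log units; within the scatter) that is estimated to stay within the scatter. Compound 3 is therefore expected to give about 2800 nM, with a plausible range from 1000 nM to 8000 nM.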

Compound 3, inhibition constant: 3000 nM
Compound 3: middle estimate off by 1.1-fold (0.03 log units), on the low side; low and high end bracket the measured number.
By their numbers in this assay, from the lowest: compound 1; then compounds 2 and 3 (each within the scatter of the next).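

In this assay, putting a methyl in place of hydrogen on the sulfonamide nitrogen gives no change at the digits printed from compound 2 to compound 3 (within the scatter), so the methylsulfamoyl and dimethylsulfamoyl groups cannot be told apart here. The hydrogen on that nitrogen is thus not needed for the gap to methoxy to appear: with no hydrogen left there, dimethylsulfamoyl in place of methoxy on the aromatic carbon still gives a 33-fold higher number from compound 1 to compound 3 (1.51 log units; beyond the scatter), a large step of the same printed size as the one seen with methylsulfamoyl. No evidence at hand accounts for either step or for the match between the two sulfonamides.

Going by these compounds, it remains open whether the higher numbers go with the sulfonyl unit itself or with any replacement of methoxy on that aromatic carbon, a question that a methylsulfonyl group, a primary sulfamoyl group with two hydrogens on its nitrogen, or a simple amine there could help to settle. Also open, on these data alone, is whether an ethoxy or hydroxy group at the same place would give a number near that of compound 1, at 92 nM.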